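Methyl in Place of Fluoro: Expecting Compound 4

The compounds below may be only part of what the source reports. "The series", "measured", "known", "first", "only" and "open" are said of these compounds alone.

Measured compounds:
compound 1 `COc1cc(-n2ncnc2-c2ccc(OC(C)C)cc2)cc(OC)c1OC`: > 10000 nM
compound 2 `COc1ccccc1-c1ncnn1-c1cc(OC)c(OC)c(OC)c1`: > 10000 nM
compound 3 `COc1cc(-n2ncnc2-c2ccc(F)cc2)cc(OC)c1OC`: > 10000 nM

In a functional assay on A549 cells (Homo sapiens) for antiproliferative activity, read by MTT assay, with a stated time of 72 h (a higher number here means a weaker inhibitor, a lower number a stronger inhibitor), compound 1 gives > 10000 nM, which is a limit of the assay and not a number. Compound 2 gives > 10000 nM, again a limit rather than a number. Compound 3 gives > 10000 nM, also a limit. Compound 3 thus stands at the limit of > 10000 nM in this assay, at which 3 of the 3 values shown sit.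

Compound 4 `COc1cc(-n2ncnc2-c2ccc(C)cc2)cc(OC)c1OC` differs from compound 3 in one place: methyl in place of fluoro on an aromatic carbon. Two measured steps lead into compound 3, namely a step that the two limits leave unreadable from compound 1 to compound 3 and a step that the two limits leave unreadable from compound 2 to compound 3; both run between limits, so their size cannot be read. Among the compounds with values here, no measured step concerns the exchange of fluoro for methyl, and all three measured compounds sit at the same limit in this assay. Compound 4 is therefore expected to stay at that limit as well, the expected step being a step that the limit leaves unreadable from compound 3 to compound 4. The estimate for compound 4 is 20000 nM, expected to lie between 6000 nM and 80000 nM.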

Compound 4, half-maximal inhibitory concentration: 1100 nM
For compound 4 the middle estimate is 18-fold (1.26 log units) above the measured one; the whole stated range lies above it.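

In this assay the aromatic carbon para to a large group proves responsive to what it carries: methyl in place of fluoro, an exchange of one heavy atom for one heavy atom, gives an at least 9.0-fold lower number from compound 3 to compound 4 (0.95 log units; beyond the scatter). Methyl in place of isopropoxy at that carbon gives an at least 9.0-fold lower number from compound 1 to compound 4 (0.95 log units; beyond the scatter), and 4-methylphenyl in place of 2-methoxyphenyl gives an at least 9.0-fold lower number from compound 2 to compound 4 (0.95 log units; beyond the scatter). Among the compounds shown, only compound 4 carries a readable value, and the others remain at the limit: the limit of > 10000 nM in this assay, at which 3 of the 4 values shown sit.

From the compounds shown here alone, the full size of these steps stays unknown, and the steps among compound 1, compound 2 and compound 3 cannot be read. Going by these compounds, it remains open whether ethyl, chloro, trifluoromethyl or an amine on the same carbon would keep, extend or lose the activity seen with methyl.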